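The source may report more compounds than this note shows. Statements on the series, on what has been measured and on what is new or still open speak of the compounds shown alone.

Compound 3 `COc1cc(/C=C/C(=O)c2cccc(NC(=O)C(C)C)c2)ccc1O` gives 56% in a functional assay on HUVEC cells (Homo sapiens) for inhibition, tested at 10 ug/mL (on this read-out higher numbers stand for a stronger effect at the one concentration tested and lower numbers for a weaker effect), the smallest of the three numbers shown, though compound 1 `COc1cc(/C=C/C(=O)c2cccc(NC(=O)c3cc(Cl)cc(Cl)c3)c2)ccc1O`, at 58%, lies within the scatter of it, and compound 2 `COc1cc(/C=C/C(=O)c2cccc(NC(=O)c3ccc(Cl)cc3Cl)c2)ccc1O` gives 70%. Compound 4 `CCCC(=O)Nc1cccc(C(=O)/C=C/c2ccc(O)c(OC)c2)c1` differs from compound 3 by propyl in place of isopropyl on a carbonyl carbon. Among the measured compounds shown here, no measured step rearranges a chain in this way; the steps that touch the isopropyl amide, a number 2 percentage points lower from compound 1 to compound 3 (within the scatter) and a number 14 percentage points lower from compound 2 to compound 3 (beyond the scatter), exchange it for a dichlorophenyl and move the number modestly at most. Straightening the isopropyl into a propyl is therefore expected to give no change at the digits printed from compound 3 to compound 4 (within the scatter), nothing beyond the scatter. Compound 4 is estimated at 56%, between 40% and 70%.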

Compound 4, a percentage reported as inhibition, at one concentration (the size of the read-out at that concentration, not a potency): 87%
Beside the measured number, compound 4's estimate is 31 percentage points below it, outside the stated range (above it).
By their numbers in this assay, from the lowest: compounds 3 and 1 (each within the scatter of the next); then compound 2; then compound 4.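

At this place, on a carbonyl carbon whose other neighbour is an amide-type nitrogen, the way the same carbons are joined matters: propyl in place of isopropyl gives a number 31 percentage points higher from compound 3 to compound 4 (beyond the scatter) in the largest step seen so far. Propyl also surpasses both dichlorophenyl groups, with a number 17 percentage points higher from compound 2 to compound 4 (beyond the scatter) and a number 29 percentage points higher from compound 1 to compound 4 (beyond the scatter) in a clear lead, so a small straight chain outperforms these larger ring groups here. No measured evidence accounts for this jump.

From the compounds shown here alone, whether ethyl or a longer chain such as butyl or pentyl would hold this level remains open. So does the effect of an amine or a carboxylic acid at the end of the propyl chain.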